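Hydroxy to hydrogen on a saturated ring carbon: two cores

This account rests on a few compounds, and the source may have more. Where it says the series, first, only, none or still open, it means among the compounds named here.

Compound 1 `C=C1CC[C@@H]2CCc3coc(c3C2(C)C)C/C(C)=C/C(O)C1` and compound 2 `C=C1CC/C=C(\C)Cc2occ3c2C(C)(C)[C@H](CC1)CC3` share one core. In a functional assay on P388 cells (Mus musculus) for cytotoxicity, read by MTT assay, with a stated time of 3 days (on this read-out higher numbers stand for an effect only at larger amounts of compound and lower numbers for an effect already at smaller amounts), compound 1 gives 3.66 ug/mL, and in this assay compound 2 gives 3.23 ug/mL. The change between them is hydrogen in place of hydroxy on a saturated ring carbon and gave a 1.1-fold lower number from compound 1 to compound 2 (0.05 log units; within the scatter). Compound 3 `C=C1CC[C@@H]2CCC3=C(C(=O)[C@@H](/C(C)=C/C(O)C1)[C@H]3O)C2(C)C` rests on a different core; the difference between the two cores is not broken down here. In this assay compound 3 reaches only > 50 ug/mL, a limit of the assay and not a number (the limit of > 50 ug/mL in this assay, at which 1 of the 3 values shown sits). Compound 4 `C=C1CC/C=C(\C)[C@@H]2C(=O)C3=C(CC[C@@H](CC1)C3(C)C)[C@@H]2O` differs from compound 3 by hydrogen in place of hydroxy on a saturated ring carbon. This is the same kind of change as that from compound 1 to compound 2, though here the place also lies three ring bonds from the ring atom that bears a fused ring. The step that the limit leaves unreadable from compound 3 to compound 4 is expected to be small because a 1.1-fold lower number from compound 1 to compound 2 (0.05 log units; within the scatter) lay within the scatter. For compound 4 the estimate in this assay is 60 ug/mL, from 25 ug/mL to 150 ug/mL, most probably again only a limit.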

Compound 4, concentration for half-maximal effect: > 50 ug/mL
Compound 4 ended at the assay's limit (the forecaster's own chance of this, stated with the estimate: 70%); the middle value is on the limit's open side.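

In this assay, compound 3 and compound 4 both end at a limit of the assay and not at a number, so no step between them can be read: the limit of > 50 ug/mL in this assay, at which 2 of the 4 values shown sit.

From the compounds shown here alone, what hydrogen in place of hydroxy on a saturated ring carbon does on the core of compound 3 stays open.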